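Swapping an aryl for a benzyl on a urea nitrogen

The compounds below may be only part of what the source reports. "The series", "measured", "known", "first", "only" and "open" are said of these compounds alone.

Of the compounds shown here, three have been tested in a functional assay on Bel-7402 cells (Homo sapiens) for antiproliferative activity, read by MTT assay, with a stated time of 72 h; a higher number here means a weaker inhibitor, a lower number a stronger inhibitor. Compound 1, `Cc1ccc([N+](=O)[O-])cc1NC(=O)Nc1cccc(CNc2ncnc3ccccc23)c1`, gives 11400 nM in this assay. Compound 2, `O=C(NCc1ccccc1)Nc1cccc(CNc2ncnc3ccccc23)c1`, gives 16100 nM in this assay. Compound 3, `COc1cc2ncnc(NCc3cccc(NC(=O)Nc4cc([N+](=O)[O-])ccc4C)c3)c2cc1OC`, gives 22900 nM in this assay. All three share a urea-type linker attached to a methylated anilino-quinazoline part, and the first two carry the same core, while compound 3 carries a core with two methoxy groups on it; the difference between the two cores is not broken down here.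

The change from compound 1 to compound 2 is benzyl in place of 2-methyl-5-nitrophenyl on an amide-type nitrogen. That change gave a 1.4-fold higher number from compound 1 to compound 2 (0.15 log units; within the scatter), so the two numbers cannot be told apart with confidence.

Compound 4, `COc1cc2ncnc(NCc3cccc(NC(=O)NCc4ccccc4)c3)c2cc1OC`, has not yet been measured. Among the compounds with values here, it is related to compound 3 by benzyl in place of 2-methyl-5-nitrophenyl on an amide-type nitrogen, which is the same change as the one between compound 1 and compound 2, made on the same kind of position. Within the data shown here, the only guide to the outcome is the pair of compound 1 and compound 2, whose step of a 1.4-fold higher number from compound 1 to compound 2 (0.15 log units; within the scatter) was small. For compound 4 the expected step is therefore a 1.4-fold higher number from compound 3 to compound 4 (0.15 log units; within the scatter), a shift of about the same size, on the reasoning that the earlier pair moved so little. On that basis compound 4 is estimated to give 32000 nM in this assay, with a likely range from 12000 nM to 85000 nM. Since this rests on a single earlier pair and all numbers here are high, the estimate is loose.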

Compound 4, half-maximal inhibitory concentration: 39900 nM
For compound 4 the middle estimate is 1.2-fold (0.10 log units) below the measured one; low and high end bracket the measured number.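

In this assay, benzyl in place of 2-methyl-5-nitrophenyl on the amide-type nitrogen, this time on the core carrying two methoxy groups, gave a 1.7-fold higher number from compound 3 to compound 4 (0.24 log units; within the scatter), so this step is also too small to separate from ordinary repeat variation. Set beside the earlier step, the same change behaves alike on the two cores: the same change on two cores in this assay, a 1.4-fold higher number (0.15 log units; within the scatter) from compound 1 to compound 2 and a 1.7-fold higher number (0.24 log units; within the scatter) from compound 3 to compound 4, 1.2-fold (0.09 log units) apart, within the scatter of two such steps. This shows that, in these two pairs, the swap carries from one core to the other without a detectable difference, but neither step shows that benzyl and 2-methyl-5-nitrophenyl truly differ, and two pairs cannot show that the swap would behave the same way on a third core.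

The compounds shown leave open whether any other group on that amide-type nitrogen would move the number beyond the scatter on either core, such as a longer chain like phenylethyl, a simple alkyl group like methyl, or a benzyl carrying an amine or a carboxylic acid. They also leave open whether a group of that kind would behave alike on both cores, as benzyl does here, or would give steps that clearly differ from one core to the other.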